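This account rests on a few compounds, and the source may have more. Where it says the series, first, only, none or still open, it means among the compounds named here.

Compound 2 `CCCCCCCCc1ccc(OCC(=O)Cn2nnnc2-c2cccs2)cc1` is the reference point of this series. Among the measured compounds shown here, in an assay on microsomes from brain for inhibition of Fatty-acid amide hydrolase 1 (Rattus norvegicus), read by fluorescence and HPLC, with a stated time of 60 min (on this read-out lower numbers stand for stronger inhibition and higher numbers for weaker inhibition), compound 2 gives 55 nM, the lowest of the two numbers so far. For the measured compounds named here, its only measured neighbour is compound 1 `CCCCCCCCc1ccc(OCC(=O)Cn2nnnc2-c2ccc(Cl)cc2)cc1`, which in this assay gives 130 nM; the exchange of one aromatic ring for another produced a 2.4-fold lower number from compound 1 to compound 2 (0.37 log units; beyond the scatter).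

The next compound, compound 3 `CCCCCCCCc1ccc(OCC(=O)Cn2nnnc2C(=O)OC)cc1`, departs from compound 2 by the change (methoxycarbonyl in place of thiophen-2-yl on an aromatic carbon). Going by the values given here, no measured step concerns this kind of replacement: the single step from compound 1 to compound 2 swapped one five-membered aromatic ring for a six-membered one, whereas here an aromatic ring leaves and a methoxycarbonyl group without a ring enters. That step is therefore only a loose guide to the size of a change at this position, and no guide to its direction. With nothing that bears on it directly, the expectation for compound 3 is a moderately higher number, shown as a 5.5-fold higher number from compound 2 to compound 3 (0.74 log units; beyond the scatter), with a wide margin on either side. Compound 3 is accordingly estimated in this assay at 300 nM, within a range from 60 nM to 1500 nM.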

Compound 3, half-maximal inhibitory concentration: 1000 nM
Beside the measured number, compound 3's estimate is 3.3-fold (0.52 log units) below it; the measured number falls inside the stated range.
By their numbers in this assay, from the lowest: compound 2; then compound 1; then compound 3.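

In this assay, this position on the aromatic carbon of the five-membered ring with four nitrogens proves far more sensitive to losing an aromatic ring than to exchanging one aromatic ring for another. The exchange of rings gave only a 2.4-fold lower number from compound 1 to compound 2 (0.37 log units; beyond the scatter), whereas methoxycarbonyl in place of thiophen-2-yl gives an 18-fold higher number from compound 2 to compound 3 (1.26 log units; beyond the scatter), and methoxycarbonyl in place of 4-chlorophenyl gives a 7.7-fold higher number from compound 1 to compound 3 (0.89 log units; beyond the scatter). Among the compounds shown here, both compounds with an aromatic ring here thus give lower numbers than the one compound without a ring, although no evidence at hand says which aspect of this replacement accounts for the rise.

With only one ringless group in view, these compounds leave open whether the higher number goes with the absence of a ring or with the methyl ester itself, a question that a carboxylic acid, a primary amide or a plain butyl chain at this position would address. They also leave open how far the aromatic series extends, for instance to unsubstituted phenyl, furan-2-yl or pyridin-2-yl.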